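A Methyl Added to the Phenyl Ring of Compound 3

This account rests on a few compounds, and the source may have more. Where it says the series, first, only, none or still open, it means among the compounds named here.

Compound 3 `NS(=O)(=O)c1ccc(N2N=C(c3ccc(Oc4ccccc4)cc3)CC2c2ccccc2)cc1` gives 42000 nM in an ADME assay on MT4 cells (Homo sapiens) for cytotoxicity, read by MTT assay, with a stated time of 96 h (on this read-out higher numbers stand for lower toxicity in this test and lower numbers for higher toxicity in this test), the highest of the three numbers shown, though both gaps are within the scatter: compound 1 `NS(=O)(=O)c1ccc(N2N=C(c3ccc(Oc4ccccc4)cc3)CC2c2ccccc2F)cc1` gives 36000 nM and compound 2 `NS(=O)(=O)c1ccc(N2N=C(c3ccc(Oc4ccccc4)cc3)CC2c2ccc(F)cc2)cc1` gives 33000 nM. Compound 4 `Cc1ccccc1C1CC(c2ccc(Oc3ccccc3)cc2)=NN1c1ccc(S(N)(=O)=O)cc1` differs from compound 3 by methyl in place of hydrogen on an aromatic carbon. Within the data shown here, the steps that bear on this change sit on the same ring: a 1.2-fold higher number from compound 1 to compound 3 (0.07 log units; within the scatter) and a 1.3-fold higher number from compound 2 to compound 3 (0.10 log units; within the scatter), both within the scatter. So far a change on this ring has moved the read-out little. Compound 4 is therefore expected to show no step beyond the scatter, a 1.1-fold lower number from compound 3 to compound 4 (0.02 log units; within the scatter). The value of compound 4 in this assay is estimated at 40000 nM, with a range from 20000 nM to 80000 nM.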

Compound 4, half-maximal cytotoxic concentration: 36000 nM
Compound 4: middle estimate off by 1.1-fold (0.05 log units), on the high side; measured number inside the range.
By their numbers in this assay, from the lowest: compounds 2, 1, 4 and 3 (each within the scatter of the next).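

In this assay, methyl on this ring gives a 1.2-fold lower number from compound 3 to compound 4 (0.07 log units; within the scatter) and so joins fluoro as a change that stays within the scatter. Against the two fluoro compounds, the 2-methylphenyl group gives a 1.1-fold higher number from compound 2 to compound 4 (0.04 log units; within the scatter) and no change at the digits printed from compound 1 to compound 4 (within the scatter), so methyl and fluoro cannot be told apart on this read-out. Nothing shown offers an explanation for this result. The compounds shown leave open whether an amine or a carboxylic acid on this ring would move the number beyond the scatter. They also leave open what a longer chain, such as butyl, would do here.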